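The source may report more compounds than this note shows. Statements on the series, on what has been measured and on what is new or still open speak of the compounds shown alone.

In an ADME assay on S9 fraction from liver (Rattus norvegicus, strain Sprague-Dawley) for metabolic stability, read by LC-MS, using NADPH, with stated times of 5 min and 60 min, tested at 5 uM (a lower number here means that less of the compound is left, a higher number that more of the compound is left), compound 2 (`COc1cc(C2CN(C(=O)c3cc(OCCCC(=O)O)ccn3)C2)ccc1OCc1ccc(C2CC2)cc1`) stands highest of the three measured compounds at 100%, with both gaps beyond the scatter. Compound 1 (`COc1cc(C2CN(C(=O)c3cc(OC[C@@H](O)CO)ccn3)C2)ccc1OCc1ccc(C2CC2)cc1`) gives 61%, and compound 3 (`CCc1ccc(COc2ccc(C3CN(C(=O)c4cc(COC[C@@H](O)CO)ccn4)C3)cc2OC)cc1`) gives 13%. Compound 4 (`COc1cc(C2CN(C(=O)c3cc(COCC(CO)CO)ccn3)C2)ccc1OCc1ccc(C2CC2)cc1`) differs from compound 2 by (3-hydroxy-2-(hydroxymethyl)propoxy)methyl in place of 3-carboxypropoxy on an aromatic carbon. Going by the values given here, the one measured step that bears directly on this is large and beyond the scatter: a number 39 percentage points higher from compound 1 to compound 2 (beyond the scatter). There, a carboxyl-ended chain replaced a hydroxyl-bearing one, whereas the change to compound 4 runs the other way, from a carboxyl-ended chain to a hydroxyl-bearing one. Compound 3 also carries hydroxyl groups on an ether chain attached through a carbon, and it gives 13%, although it differs from compound 4 elsewhere too. A large fall in this assay is therefore expected, with an estimated a number 65 percentage points lower from compound 2 to compound 4 (beyond the scatter). Compound 4 is estimated at 35%, with an expected range from 10% to 65%.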

Compound 4, percent of the compound remaining: 29%
Compound 4: the middle estimate sits 6 percentage points above what was measured, within the range that was stated.
By their numbers in this assay, from the lowest: compound 3; then compound 4; then compound 1; then compound 2.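

In this assay, the carboxyl-ended chain and the (3-hydroxy-2-(hydroxymethyl)propoxy)methyl group on this aromatic carbon, opposite the ring nitrogen, are far apart, with a number 71 percentage points lower from compound 2 to compound 4 (beyond the scatter) as a large step. The earlier compounds shown here did not show that hydroxyl-bearing chains at this position can differ widely from one another, yet the change from 2,3-dihydroxypropoxy gives a number 32 percentage points lower from compound 1 to compound 4 (beyond the scatter), also large and beyond the scatter. Nothing available explains either step.

Both steps alter the end of the chain and its attachment to the ring together, so the compounds shown leave open which of these changes carries the fall. On these data alone, how a carboxylic acid or an amine at the end of a chain attached as in compound 4 would stand also remains open.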